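Removing a Methyl from a Fused Core, Twice

A few compounds are considered here, and "the series" means these few. Any claim that something is new, unique, unknown or untested is made for them only; others in the source may bear on it.

Compound 1, `Cc1nsc2c1nc(SCc1ccccc1)n2[C@H]1C[C@H](O)[C@@H](CO)O1`, in a functional assay on HFF cells (Homo sapiens) for inhibition; a higher number here means a weaker inhibitor, a lower number a stronger inhibitor: > 100000 nM, a limit of the assay.
Compound 2, `OC[C@H]1O[C@@H](n2c(SCc3ccccc3)nc3cnsc32)C[C@@H]1O`, in this assay: > 100000 nM, a limit of the assay.
Compound 3, `CSc1nc2c(C)nsc2n1[C@@H]1O[C@H](CO)[C@@H](O)[C@H]1O`, in this assay: > 100000 nM, a limit of the assay.

Compound 1 and compound 2 share a core and differ in a single place: hydrogen in place of methyl on an aromatic carbon. Both values are limits, so the step that the two limits leave unreadable from compound 1 to compound 2 cannot be sized from what was recorded. Compound 3 carries a different core and a different sugar; the difference between the core of compound 1 and the core of compound 3 is not broken down here. What unites all three measured compounds is the limit of > 100000 nM in this assay, at which 3 of the 3 values shown sit.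

Compound 4, `CSc1nc2cnsc2n1[C@@H]1O[C@H](CO)[C@@H](O)[C@H]1O`, has not yet been measured in this assay. It differs from compound 3 by hydrogen in place of methyl on an aromatic carbon, the same change that separates compound 1 from compound 2.

The expectation for compound 4 rests on two things: compound 3 gives only a limit in this assay, and the earlier, matched change left both of its partners at that limit, as the limit of > 100000 nM in this assay, at which 3 of the 3 values shown sit, shows. The expected step is therefore a number no higher from compound 3 to compound 4 (the limit leaves the size open), taken as no visible movement. Compound 4 is estimated at 100000 nM in this assay, with a likely range from 40000 nM to 300000 nM, and most probably it too will return only a limit rather than a number.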

Compound 4, half-maximal inhibitory concentration: > 100000 nM
Compound 4 was reported as a limit (the forecaster's own chance of this, stated with the estimate: 85%); the middle value sits exactly at the limit.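

Compound 3 and compound 4 both return only a limit in this assay, so the step between them, hydrogen in place of methyl on an aromatic carbon, cannot be read. The four compounds share a single result: the limit of > 100000 nM in this assay, at which 4 of the 4 values shown sit.

The compounds shown leave open whether this change affects inhibition at all, and what structure would give a readable value in this assay.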